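Solubility notes: aryl swap on the pyrrole nitrogen

The source may report more compounds than this note shows. Statements on the series, on what has been measured and on what is new or still open speak of the compounds shown alone.

Measured so far:
- compound 1, `CCOC(=O)C1=C(C)N/C(=C/c2cc(C)n(-c3ccc(CN(C)C)cc3)c2C)C1=O`: 12.5 ug/mL
- compound 2, `CCOC(=O)C1=C(C)N/C(=C/c2cc(C)n(-c3ccc(Cl)cc3)c2C)C1=O`: 1.6 ug/mL
- compound 3, `CCOC(=O)C1=C(C)N/C(=C/c2cc(C)n(-c3ccc(SC)cc3)c2C)C1=O`: 1.6 ug/mL

All three share one core and differ only in the group on the aromatic carbon of the ring attached to the pyrrole nitrogen. In a physicochemical assay for solubility, read by nephelometry, in phosphate buffer, measured as kinetic solubility, at pH 6.5 (on this read-out lower numbers stand for lower solubility and higher numbers for higher solubility), compound 3 stands level with compound 2 and the two together give the lowest numbers; the step of no change at the digits printed from compound 2 to compound 3 (within the scatter) is within the scatter, while a 7.8-fold lower number from compound 1 to compound 3 (0.89 log units; beyond the scatter) is beyond it, so compound 1 is the only one of the three that sits clearly apart.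

Compound 4, `CCOC(=O)C1=C(C)N/C(=C/c2cc(C)n(-c3cccnc3)c2C)C1=O`, is not yet measured. The change from compound 3 is pyridin-3-yl in place of 4-(methylsulfanyl)phenyl on an aromatic nitrogen. For the measured compounds named here, no measured step exchanges the whole ring; the two steps that bear on it, a 7.8-fold lower number from compound 1 to compound 3 (0.89 log units; beyond the scatter) and no change at the digits printed from compound 2 to compound 3 (within the scatter), only vary the group on the aromatic carbon of that ring and span a modest range. On this basis compound 4 is expected to move up in this assay by a 3.1-fold higher number from compound 3 to compound 4 (0.49 log units; beyond the scatter), with the estimate for compound 4 put at 5 ug/mL, within 1.5 ug/mL to 20 ug/mL.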

Compound 4, solubility: 25 ug/mL
Compound 4: middle estimate off by 5.0-fold (0.70 log units), on the low side; measured number above the stated range.
By their numbers in this assay, from the lowest: compounds 2 and 3 (each within the scatter of the next); then compounds 1 and 4 (each within the scatter of the next).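

Exchanging the whole ring on the aromatic nitrogen moves the number in this assay further than any change of the group on that ring, (a 16-fold higher number from compound 3 to compound 4 (1.19 log units; beyond the scatter)) and (a 16-fold higher number from compound 2 to compound 4 (1.19 log units; beyond the scatter)), against (a 7.8-fold lower number from compound 1 to compound 2 (0.89 log units; beyond the scatter)) for the earlier change. Two different rings on that nitrogen, pyridin-3-yl and 4-((dimethylamino)methyl)phenyl, now share the top level (a 2.0-fold higher number from compound 1 to compound 4 (0.30 log units; within the scatter)), so a (dimethylamino)methyl group is not the only route to it in this series. Nothing measured alongside these numbers accounts for the size of the step.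

An unsubstituted phenyl on the same nitrogen would show how much of the step belongs to the ring nitrogen and how much to the loss of the chloro or methylsulfanyl group. Pyridin-2-yl and pyridin-4-yl would show whether the place of that ring nitrogen counts.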